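Notes on the step from compound 3 to compound 4

This account rests on a few compounds, and the source may have more. Where it says the series, first, only, none or still open, it means among the compounds named here.

Measured in a physicochemical assay for lipophilicity; on this read-out lower numbers stand for lower lipophilicity and higher numbers for higher lipophilicity:
- compound 1 `CC(=O)OC[C@H]1C[C@]2(OC(=O)/C=C/c3ccccc3)C(=O)/C(C)=C/[C@@H]3[C@H](CC[C@@]4(C)O[C@@H]4[C@H]2[C@H]1O)C3(C)C`: 5.5
- compound 2 `C/C1=C\[C@@H]2[C@H](CC[C@@]3(C)O[C@@H]3[C@H]3[C@@H](O)[C@@H](CO)C[C@]3(OC(=O)/C=C/c3ccccc3)C1=O)C2(C)C`: 4.8
- compound 3 `C/C1=C\[C@@H]2[C@H](CC[C@@]3(C)O[C@@H]3[C@H]3[C@@H](O)[C@@H](COC(=O)c4ccccc4)C[C@]3(OC(=O)/C=C/c3ccccc3)C1=O)C2(C)C`: 7.2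

Of the three, compound 3 stands highest at 7.2, and its gaps to the other two lie beyond the scatter. Compound 4 `C/C1=C\[C@@H]2[C@H](CC[C@@]3(C)O[C@@H]3[C@H]3[C@@H](O)[C@@H](C)C[C@]3(OC(=O)/C=C/c3ccccc3)C1=O)C2(C)C` carries hydrogen in place of benzoyloxy on a saturated chain carbon bound to a saturated ring carbon. The closest measured change, benzoyl in place of hydrogen on an oxygen, gives a number 2.40 log units higher from compound 2 to compound 3 (beyond the scatter). The change from acetyl to benzoyl gives a number 1.70 log units higher from compound 1 to compound 3 (beyond the scatter), and losing the acetyl gives a number 0.70 log units lower from compound 1 to compound 2 (beyond the scatter). Going by the values given here, no measured compound shows the loss of the oxygen itself. A large downward step is expected in this assay: compound 2 also lacks the benzoyl and gives 4.8. The estimated step is a number 1.60 log units lower from compound 3 to compound 4 (beyond the scatter). For compound 4 the expected value is 5.6, with an estimated range from 5 to 6.3.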

Compound 4, partition coefficient: 5.8
Estimate against measurement, compound 4: 0.20 log units below, within the range that was stated.
By their numbers in this assay, from the lowest: compound 2; then compounds 1 and 4 (each within the scatter of the next); then compound 3.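

In this assay, going by these compounds alone, hydrogen in place of hydroxy on a saturated chain carbon bound to a saturated ring carbon gives a number 1.00 log units higher from compound 2 to compound 4 (beyond the scatter) and is the first read of the loss of the oxygen itself at this position. Hydrogen in place of benzoyloxy gives a number 1.40 log units lower from compound 3 to compound 4 (beyond the scatter) and so sets the whole benzoyloxy against the plain methyl. Hydrogen in place of acetoxy gives a number 0.30 log units higher from compound 1 to compound 4 (within the scatter) and leaves acetoxy and methyl not told apart at this position, whereas hydroxy and benzoyloxy each stand clear of methyl, on opposite sides.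

Going by these compounds, how an amine, a carboxylic acid or a longer chain on this carbon would read in this assay stays open. The size of these steps also remains unexplained, with nothing at hand that bears on it.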